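The source may hold more compounds than are shown below. What is called first, only, known or untested is meant among the compounds shown, and "the series" means these compounds.

Compound 1: `CCOC(=O)N1CCC(NS(=O)(=O)c2ccc(NCc3ccccc3)c3ccccc23)CC1`, which in an assay on L1.2 cells for binding affinity to C-C chemokine receptor type 8 (Homo sapiens) (a lower number here means a stronger inhibitor, a higher number a weaker inhibitor), gives 45.6 nM.
Compound 2: `CCC(=O)N1CCC(NS(=O)(=O)c2ccc(NC(=O)c3ccccc3C)c3ccccc23)CC1`, which in this assay gives 2.5 nM.

Of these two measured compounds, compound 2 gives the lower number and so is the stronger inhibitor, and compound 1 gives the higher number; that gap lies beyond the usual scatter of this assay. The two compounds differ in several places at once, so no single structural change can be tied to the gap between them.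

Compound 3 is `Cc1ccccc1C(=O)Nc1ccc(S(=O)(=O)NC2CCN(C(=O)CCCN)CC2)c2ccccc12`. It differs from compound 2 in one place: aminomethyl in place of hydrogen on a saturated chain carbon, two bonds along the chain from a carbonyl carbon. This change sits on the chain that caps the saturated ring, well away from the part of the molecule that compounds 1 and 2 share in common. Going by the values given here, no measured pair shows what such a change does here. The expectation is a step from compound 2 to compound 3 of a 1.6-fold higher number from compound 2 to compound 3 (0.20 log units; within the scatter), which is within the usual scatter. Compound 3 is therefore expected to give about 4 nM, with a likely range from 1.5 nM to 12 nM.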

Compound 3, inhibition constant: 1.6 nM
The estimate for compound 3 lay 2.5-fold (0.40 log units) above the measured number; the measured number falls inside the stated range.
By their numbers in this assay, from the lowest: compounds 3 and 2 (each within the scatter of the next); then compound 1.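

Going by these compounds alone, this is the first comparison that changes only one place, and it concerns the chain capping the saturated ring. In this assay, a 1.6-fold lower number from compound 2 to compound 3 (0.19 log units; within the scatter) comes with turning propanoyl into (3-aminopropyl)carbonyl, so compound 3 and compound 2 cannot be told apart, even though the new group adds an amine. At this position, then, a longer chain that ends in an amine is compatible with a low number in this assay, but nothing measured here explains this result.

Going by these compounds, it remains open how a hydroxyl, a carboxylic acid or a still longer chain would behave at this place, and whether the amine or the added chain length matters more. On these data alone, it is also open whether aminomethyl would give a similar step on another cap.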